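This account rests on a few compounds, and the source may have more. Where it says the series, first, only, none or still open, it means among the compounds named here.

The three measured compounds, in a functional assay on Jurkat cells for inhibition of nuclear factor NF-kappa-B complex (Homo sapiens); on this read-out lower numbers stand for stronger inhibition and higher numbers for weaker inhibition:
compound 1 `CCOC(=O)c1cnc(C(F)(F)F)nc1NN1C(=O)C=C(C)C1=O` gives 1000 nM;
compound 2 `CCOC(=O)c1cnc(-c2ccncc2)nc1NN1C(=O)C=C(C)C1=O` gives 6000 nM;
compound 3 `CCOC(=O)c1cnc(-c2cccc([N+](=O)[O-])c2)nc1NN1C(=O)C=C(C)C1=O` gives 7000 nM.

Compound 3 has the highest number of the three. The step of a 1.2-fold higher number from compound 2 to compound 3 (0.07 log units; within the scatter) is small, so compound 2 and compound 3 cannot be told apart, while a 7.0-fold higher number from compound 1 to compound 3 (0.85 log units; beyond the scatter) sets compound 3 clearly apart from compound 1. Compound 4 `CCOC(=O)c1cnc(CC2=CCCCC2)nc1NN1C(=O)C=C(C)C1=O` is not yet measured; it differs from compound 3 in one place: (cyclohex-1-en-1-yl)methyl in place of 3-nitrophenyl on an aromatic carbon. Among the compounds with values here, no measured step involves this incoming group, so no step bears on it directly. The nearest guides are a 6.0-fold higher number from compound 1 to compound 2 (0.78 log units; beyond the scatter) and a 7.0-fold higher number from compound 1 to compound 3 (0.85 log units; beyond the scatter), which show that exchanging trifluoromethyl for either of the two larger groups raised the number, and a 1.2-fold higher number from compound 2 to compound 3 (0.07 log units; within the scatter), which shows that those two larger groups gave numbers that do not differ. The incoming group is unlike any of the three already tried, so the direction is uncertain and the step expected is a 2.3-fold lower number from compound 3 to compound 4 (0.37 log units; beyond the scatter), with wide bounds. Compound 4 is therefore estimated at 3000 nM, with an expected range from 700 nM to 15000 nM.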

Compound 4, half-maximal inhibitory concentration: 2000 nM
The estimate for compound 4 lay 1.5-fold (0.18 log units) above the measured number; low and high end bracket the measured number.
By their numbers in this assay, from the lowest: compounds 1 and 4 (each within the scatter of the next); then compounds 2 and 3 (each within the scatter of the next).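

In this assay, the change to (cyclohex-1-en-1-yl)methyl on the aromatic carbon between two ring nitrogen atoms gives a 3.5-fold lower number from compound 3 to compound 4 (0.54 log units; beyond the scatter) and a 3.0-fold lower number from compound 2 to compound 4 (0.48 log units; beyond the scatter), so at this position the three groups that carry a ring do not all behave alike. The further step, a 2.0-fold higher number from compound 1 to compound 4 (0.30 log units; within the scatter), lies within the scatter, so compound 1 and compound 4 cannot be told apart. The earlier compounds shown here could suggest that any ring-bearing group here weakens inhibition relative to trifluoromethyl, but compound 4 does not fit that reading, and only compound 2 and compound 3, with their aromatic rings, stand apart from compound 1.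

Nothing given here explains why these groups differ. On these data alone, it remains open how a cyclohexylmethyl group, a plain butyl chain or a dimethylamino group would read at this position.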